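The source may hold more compounds than are shown below. What is called first, only, known or untested is meant among the compounds shown, and "the series" means these compounds.

Three analogues built on one shared core have been measured in an ADME assay on the whole organism (plasma) for pharmacokinetics, with Rattus norvegicus as the target, with a stated time of 6 h, at a dose of 10 mg/kg by the oral route; a lower number here means less compound in the circulation, a higher number more compound in the circulation at the dose given. Compound 1 `CNc1nc(C)c(-c2nc3ccccc3s2)c(N[C@@H]2C[C@H](CO)[C@@H](O)[C@H]2O)n1` gives 1080 ng.h/mL in this assay. Compound 2 `COCCNc1nc(C)c(-c2nc3ccccc3s2)c(N[C@@H]2C[C@H](CO)[C@@H](O)[C@H]2O)n1` gives 2630 ng.h/mL, and compound 3 `Cc1nc(Nc2ccccc2)nc(N[C@@H]2C[C@H](CO)[C@@H](O)[C@H]2O)c1-c1nc2ccccc2s1` gives 742 ng.h/mL. Compound 2 thus stands highest of the three numbers: the rise toward it is a 2.4-fold higher number from compound 1 to compound 2 (0.39 log units; beyond the scatter), and the fall away from it is a 3.5-fold lower number from compound 2 to compound 3 (0.55 log units; beyond the scatter). The remaining step, a 1.5-fold lower number from compound 1 to compound 3 (0.16 log units; within the scatter), lies within the scatter.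

Compound 4 `Cc1nc(NCc2ccncc2)nc(N[C@@H]2C[C@H](CO)[C@@H](O)[C@H]2O)c1-c1nc2ccccc2s1` has not yet been measured in this assay. It differs from compound 2 in one place: pyridin-4-yl in place of methoxymethyl on a saturated chain carbon bound to a nitrogen on an aromatic ring. Within the data shown here, two measured steps bear on this change. The step of a 2.4-fold higher number from compound 1 to compound 2 (0.39 log units; beyond the scatter) shows that methoxymethyl in place of hydrogen on the saturated chain carbon raised the number modestly. The step of a 3.5-fold lower number from compound 2 to compound 3 (0.55 log units; beyond the scatter) shows that an aromatic ring in place of the 2-methoxyethyl chain on the nitrogen lowered it beyond the scatter. Compound 4 keeps the saturated chain carbon but carries pyridin-4-yl where compound 2 carries methoxymethyl, so a modest downward step is expected. Compound 4 is therefore estimated to give 1000 ng.h/mL, within a range from 350 ng.h/mL to 2800 ng.h/mL. The expected step is a 2.6-fold lower number from compound 2 to compound 4 (0.42 log units; beyond the scatter).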

Compound 4, area under the concentration-time curve: 47.9 ng.h/mL
Compound 4: middle estimate off by 21-fold (1.32 log units), on the high side; the measured number lies below the stated range.
By their numbers in this assay, from the lowest: compound 4; then compounds 3 and 1 (each within the scatter of the next); then compound 2.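

In this assay, among these compounds, the substituent on the saturated chain carbon bound to a nitrogen on an aromatic ring turns out to matter far more than the earlier compounds showed: pyridin-4-yl in place of methoxymethyl gives a 55-fold lower number from compound 2 to compound 4 (1.74 log units; beyond the scatter), a step of a larger class than any seen among compounds 1, 2 and 3. The loss is not confined to the comparison with compound 2, since the same compound also stands well under the methyl-bearing and phenyl-bearing analogues, with a 23-fold lower number from compound 1 to compound 4 (1.35 log units; beyond the scatter) and a 15-fold lower number from compound 3 to compound 4 (1.19 log units; beyond the scatter), so an aromatic ring set directly on the nitrogen in compound 3 gave no warning of what (pyridin-4-yl)methyl does there. Nothing measured here accounts for the drop.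

The compounds shown leave open whether the loss goes with the ring nitrogen of pyridin-4-yl or with any ring on that chain carbon, which a benzyl group on the same nitrogen would begin to separate. They also leave open whether pyridin-2-yl or pyridin-3-yl at the same place would behave like pyridin-4-yl.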